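The compounds below may be only part of what the source reports. "The series", "measured", "known", "first", "only" and "open" are said of these compounds alone.

In an assay on CHO cells for displacement of a labelled ligand from Alpha-1D adrenergic receptor (Homo sapiens) (on this read-out lower numbers stand for stronger inhibition and higher numbers for weaker inhibition), the three measured compounds give:

compound 1 `COc1cccc(OC)c1OCCNCCOc1ccccc1OCc1ccccc1` — 0.0676 nM
compound 2 `COc1cccc(OC)c1OCCNCCOc1ccccc1OCc1cccc(C)c1` — 0.2 nM
compound 3 `COc1cccc(OC)c1OCCNCCOc1ccccc1OCc1ccc(C)cc1` — 0.0631 nM

Compound 2 holds the highest number of the three, that is the weakest binding: a 3.0-fold higher number from compound 1 to compound 2 (0.47 log units; beyond the scatter) and a 3.2-fold lower number from compound 2 to compound 3 (0.50 log units; beyond the scatter), both beyond the scatter. Compound 4 `COc1cccc(OC)c1OCCNCCOc1ccccc1OCc1ccc([N+](=O)[O-])cc1` is not yet measured; it differs from compound 2 in that (4-nitrophenyl in place of 3-methylphenyl on a saturated chain carbon bound to an oxygen on an aromatic ring). The step from compound 2 to compound 3 bears on it, as it too leaves the 3-methylphenyl behind and gave a modest fall in the number. A nitro group has no measured counterpart among these compounds, so the expectation is a modest fall with wide uncertainty, a 2.0-fold lower number from compound 2 to compound 4 (0.30 log units; within the scatter). Compound 4 is therefore estimated at 0.1 nM, within a range from 0.03 nM to 0.4 nM.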

Compound 4, inhibition constant: 0.0501 nM
Estimate against measurement, compound 4: 2.0-fold (0.30 log units) above; measured number inside the range.
By their numbers in this assay, from the lowest: compounds 4, 3 and 1 (each within the scatter of the next); then compound 2.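

At this position, a nitro group is accepted as readily as a methyl or a plain hydrogen: in this assay, a 1.3-fold lower number from compound 3 to compound 4 (0.10 log units; within the scatter) and a 1.3-fold lower number from compound 1 to compound 4 (0.13 log units; within the scatter). The 3-methylphenyl group alone stands apart among the four compounds, with a 4.0-fold lower number from compound 2 to compound 4 (0.60 log units; beyond the scatter). Nothing measured here explains this difference. Going by these compounds, it remains open whether an amine or a carboxylic acid in place of the nitro would fit as well. On these data alone, it is also open whether a nitro at the spot the methyl occupies in the 3-methylphenyl group would give the same higher number.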